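A few compounds are considered here, and "the series" means these few. Any claim that something is new, unique, unknown or untested is made for them only; others in the source may bear on it.

Measured so far in an in vitro ADME assay on microsomes (Homo sapiens) for pharmacokinetics; on this read-out lower numbers stand for slow clearance and higher numbers for fast clearance:

compound 1 `CC1(C)CCNC(=O)C(N(Cc2ccc(C(=O)NC3CC3)cc2)S(=O)(=O)c2ccc(Cl)cc2)C1` — 45 mL.min-1.g-1
compound 2 `COc1ccc(CN([C@@H]2CC(F)(F)CCNC2=O)S(=O)(=O)c2ccc(Cl)cc2)c(F)c1F` — 19 mL.min-1.g-1

Of the two numbers in hand, compound 1 gives the higher one; the gap to compound 2 lies beyond the usual scatter, so compound 1 is the faster-cleared of the pair. Among the compounds with values here, compound 2 differs from compound 1 in more than one place, so the two values show only that the pair sits apart, not which part of the structure carries the difference.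

The next compound, compound 3 `O=C(NC1CC1)c1ccc(CN([C@@H]2CC(F)(F)CCNC2=O)S(=O)(=O)c2ccc(Cl)cc2)cc1`, keeps the benzamide side of compound 1 and changes one place: 5,5-difluoro-2-oxoazepan-3-yl in place of 5,5-dimethyl-2-oxoazepan-3-yl on a sulfonamide nitrogen. The same entering group is already present in compound 2, which sits at the low end of the series. Within the data shown here, no single-point step between measured compounds is available, so the size of the step is an expectation rather than a reading. The step from compound 1 to compound 3 is expected to be a decrease, estimated at a 2.0-fold lower number from compound 1 to compound 3 (0.31 log units; beyond the scatter), because the same entering group sits in compound 2 at 19 mL.min-1.g-1. For compound 3 in this assay the estimate is 22 mL.min-1.g-1, with a range from 10 mL.min-1.g-1 to 45 mL.min-1.g-1.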

Compound 3, intrinsic clearance in microsomes: 1.9 mL.min-1.g-1
The estimate for compound 3 lay 12-fold (1.06 log units) above the measured number; measured number below the stated range.
By their numbers in this assay, from the lowest: compound 3; then compound 2; then compound 1.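

Within the data shown here, the exchange of 5,5-dimethyl-2-oxoazepan-3-yl for 5,5-difluoro-2-oxoazepan-3-yl on a sulfonamide nitrogen gives, in this assay, a 24-fold lower number from compound 1 to compound 3 (1.37 log units; beyond the scatter), the first reading of a change in one place and a large one, so the read-out is highly sensitive to this group. The entering group does not fix the number by itself: with it in place, compound 2 gives 19 mL.min-1.g-1 and compound 3 gives 1.9 mL.min-1.g-1, so the rest of the molecule still matters. No measurement at hand accounts for the size of the step.

Going by these compounds, the entering group also carries a defined stereocentre that the leaving group lacks, so the step does not separate the exchange of methyl for fluorine from the defined stereochemistry, and the opposite stereoisomer remains open. Also open, on these data alone, is how an unsubstituted 2-oxoazepan-3-yl group, a monofluoro analogue or a hydroxy group would read in the same place, and whether the step would be of similar size with the other substituents of compound 2.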